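Replacing Dipentylamino with Anilino on the Sulfamoyl Carbamate

The compounds below may be only part of what the source reports. "The series", "measured", "known", "first", "only" and "open" are said of these compounds alone.

Compound 2 `CCCCCN(CCCCC)S(=O)(=O)NC(=O)Oc1c(C(C)(C)C)cc(C)cc1C(C)(C)C` gives 2200 nM in an assay on liver for inhibition of sterol O-acyltransferase 1 (Rattus norvegicus), using microsomes; on this read-out lower numbers stand for stronger inhibition and higher numbers for weaker inhibition. Among the compounds with values here, its only measured neighbour, compound 1 `Cc1cc(C(C)(C)C)c(OC(=O)NS(=O)(=O)N(C(C)C)C(C)C)c(C(C)(C)C)c1`, gives 3200 nM in this assay, and the single step between them, a 1.5-fold lower number from compound 1 to compound 2 (0.16 log units; within the scatter), lies within the scatter, so the two compounds cannot be separated on this read-out.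

Compound 3 `Cc1cc(C(C)(C)C)c(OC(=O)NS(=O)(=O)Nc2ccccc2)c(C(C)(C)C)c1` differs from compound 2 by anilino in place of dipentylamino on a sulfonyl sulfur. Within the data shown here, the one measured step that touches this position, a 1.5-fold lower number from compound 1 to compound 2 (0.16 log units; within the scatter), was small and exchanged one amino group bearing only chains for another of the same kind. Among the measured compounds shown here, no measured compound carries a ring or a hydrogen-bond donor on the sulfonyl sulfur, so that part of the change has no precedent here. With only a small step on record, compound 3 is expected to sit near compound 2, and the step of a 1.4-fold higher number from compound 2 to compound 3 (0.13 log units; within the scatter) is estimated to stay within the scatter. Compound 3 is therefore expected to give about 3000 nM, with a range from 800 nM to 12000 nM.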

Compound 3, half-maximal inhibitory concentration: 23400 nM
Compound 3: the middle estimate sits 7.8-fold (0.89 log units) below what was measured, outside the stated range (above it).
By their numbers in this assay, from the lowest: compounds 2 and 1 (each within the scatter of the next); then compound 3.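

The sulfonyl sulfur position is not indifferent in this assay: the two amino groups bearing only chains could not be separated, whereas anilino gives an 11-fold higher number from compound 2 to compound 3 (1.03 log units; beyond the scatter) and a 7.3-fold higher number from compound 1 to compound 3 (0.86 log units; beyond the scatter). Both steps run the same way, so compound 3, the only compound shown with a ring and a hydrogen-bond donor on the sulfonyl sulfur, is the weakest of the three. Nothing available accounts for this result.

Because anilino brings the ring and the donor together, the compounds shown leave open which of the two goes with the higher number. Cyclohexylamino, which keeps the donor on a non-aromatic ring, and methyl(phenyl)amino, which keeps the aromatic ring without the donor, would separate these two features.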